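The source may report more compounds than this note shows. Statements on the series, on what has been measured and on what is new or still open speak of the compounds shown alone.

Measured compounds in an ADME assay on Akata cells (Homo sapiens) for cytotoxicity, with a stated time of 7 days; a lower number here means that less compound is tolerated, a higher number that more compound is tolerated:

Compound 1 `CCCOc1nc(N)nc2c1ncn2/C=C1/CC1(CO)CO` gives > 20000 nM, a limit of the assay rather than a number.
Compound 2 `Nc1nc(NCc2ccccc2)c2ncn(/C=C3/CC3(CO)CO)c2n1` gives > 24000 nM, again a limit.
Compound 3 `CCCCNc1nc(N)nc2c1ncn2/C=C1/CC1(CO)CO` gives > 24000 nM, also a limit.

Compound 3 therefore stands nowhere fixed on the numbers shown: its value is a limit, and the two further values sit at limits as well, one at the limit of > 20000 nM in this assay, at which 1 of the 3 values shown sits, and two at the limit of > 24000 nM in this assay, at which 2 of the 3 values shown sit. The step from compound 3 to compound 4 `CNc1nc(N)nc2c1ncn2/C=C1/CC1(CO)CO` is hydrogen in place of propyl on a saturated chain carbon bound to a nitrogen on an aromatic ring. Among the measured compounds shown here, two measured steps touch the same place. The first, a step that the two limits leave unreadable from compound 1 to compound 3, cannot be read because both ends are limits. The second, a step that the two limits leave unreadable from compound 2 to compound 3, is unreadable for the same reason, and a step that the two limits leave unreadable from compound 1 to compound 2 adds nothing more. None of the three steps gives a size or a direction, so no step beyond the scatter can be expected in this assay from this change; the three measured compounds all sit at limits, and compound 4 is expected to do the same. Compound 4 is estimated at 30000 nM, between 15000 nM and 60000 nM, most probably reported as a limit again, with the step from compound 3 expected as a step that the limit leaves unreadable from compound 3 to compound 4.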

Compound 4, half-maximal cytotoxic concentration: > 24000 nM
Compound 4: only a limit was reported; the forecaster's own chance of this, stated with the estimate: 85%; the middle value lies beyond the limit too.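

In this assay compound 4 gives > 24000 nM, a limit of the assay and not a number. Among the compounds shown here, compound 1, compound 2 and compound 3 also stand at limits, so no step from any of them to compound 4 can be read. The compounds shown leave open at what concentration any of them reaches half-maximal cytotoxicity in this assay.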